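This account rests on a few compounds, and the source may have more. Where it says the series, first, only, none or still open, it means among the compounds named here.

Measured in a functional assay on A549 cells (Homo sapiens) for inhibition, read by sulforhodamine B assay, with a stated time of 48 h; on this read-out higher numbers stand for weaker inhibition of growth and lower numbers for stronger inhibition of growth:
- Compound 1 `COc1ccc(/C=C/C(=O)C(=Cc2ccc(N(C)C)cc2)C(=O)/C=C/c2ccc(OC)c(OC)c2)cc1OC`: 2620 nM
- Compound 2 `CCc1ccc(C=C(C(=O)/C=C/c2ccc(OC)c(OC)c2)C(=O)/C=C/c2ccc(OC)c(OC)c2)cc1`: 630 nM

Compound 2, at 630 nM, holds the lower of the two numbers in this assay. Compound 3 `COc1ccc(/C=C/C(=O)C(=Cc2cccc(OC)c2OC)C(=O)/C=C/c2ccc(OC)c(OC)c2)cc1OC` is reached from it by 2,3-dimethoxyphenyl in place of 4-ethylphenyl on a double-bonded chain carbon bound to a double-bonded chain carbon.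

Within the data shown here, only one measured step bears on this. The step of a 4.2-fold lower number from compound 1 to compound 2 (0.62 log units; beyond the scatter) is modest but beyond the scatter, and it places ethyl in place of dimethylamino on an aromatic carbon of the ring now being replaced. Among the measured compounds shown here, no measured compound has 2,3-dimethoxyphenyl at this place, so the direction is uncertain. A modest step of similar size toward a higher number is expected. The expected change is a 1.7-fold higher number from compound 2 to compound 3 (0.24 log units; within the scatter). For compound 3 the estimated value is 1100 nM, with an expected range from 400 nM to 3000 nM.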

Compound 3, concentration for 50% growth inhibition: 670 nM
Compound 3: middle estimate off by 1.6-fold (0.22 log units), on the high side; the range from low to high includes it.
By their numbers in this assay, from the lowest: compounds 2 and 3 (each within the scatter of the next); then compound 1.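

In this assay, the step of a 1.1-fold higher number from compound 2 to compound 3 (0.03 log units; within the scatter) shows that the place on a double-bonded chain carbon bound to a double-bonded chain carbon takes 2,3-dimethoxyphenyl as well as 4-ethylphenyl, with no difference beyond the scatter, although the entering group carries two hydrogen-bond acceptors and the leaving group none. The step of a 3.9-fold lower number from compound 1 to compound 3 (0.59 log units; beyond the scatter) shows that 4-(dimethylamino)phenyl stands apart from both of these groups at this place, with the higher number. No measurement at hand accounts for this result.

The compounds shown leave open whether a single methoxy group on this ring would match the pair in compound 3. Going by these compounds, it is equally open whether a carboxylic acid or a primary amine here would fall with compound 2 and compound 3 or with compound 1.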